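Chloro on the pyridine ring and cytotoxicity of vinyl sulfones

A few compounds are considered here, and "the series" means these few. Any claim that something is new, unique, unknown or untested is made for them only; others in the source may bear on it.

Compound 1, with the structure `COc1cccc(S(=O)(=O)/C=C/c2ccccn2)c1`, is one of three measured vinyl sulfones. In an ADME assay on BV-2 cells (Mus musculus) for cytotoxicity, with a stated time of 24 h, tested at 10 uM (on this read-out higher numbers stand for a weaker effect at the one concentration tested and lower numbers for a stronger effect), compound 1 gives 100%. Compound 2, `COc1cccc(S(=O)(=O)/C=C/c2ncccc2Cl)c1`, carries a (chloro in place of hydrogen on an aromatic carbon). In this assay compound 2 gives 100%, and the step of no change at the digits printed from compound 1 to compound 2 (within the scatter). Compound 3, `COc1ccc(S(=O)(=O)/C=C/c2ccccn2)cc1`, has the same atoms as compound 1 joined differently; the difference between the two cores is not broken down here. In this assay compound 3 gives 100%, level with compound 1 and compound 2.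

Compound 4, `COc1ccc(S(=O)(=O)/C=C/c2cccc(Cl)n2)cc1`, is not yet measured. It differs from compound 3 by a (chloro in place of hydrogen on an aromatic carbon). This is the same kind of change as that from compound 1 to compound 2, though not the same: there the chlorine sat ortho to a large group and two atoms from the ring nitrogen, here it sits next to the ring nitrogen and meta to a large group. Because the step of no change at the digits printed from compound 1 to compound 2 (within the scatter) stayed within the scatter, the expected step from compound 3 to compound 4 is no change at the digits printed from compound 3 to compound 4 (within the scatter). Compound 4 is therefore estimated at 100%, with a range from 88% to 108%.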

Compound 4, a percentage reported as activity, at one concentration (the size of the read-out at that concentration, not a potency): 97%
The estimate for compound 4 lay 3 percentage points above the measured number, and the stated range covers the measured number.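

In this assay, chloro in place of hydrogen on an aromatic carbon gave a number 3 percentage points lower from compound 3 to compound 4 (within the scatter), and set beside the earlier step, the two cores do not differ: the same change on two cores in this assay, no change at the digits printed (within the scatter) from compound 1 to compound 2 and a number 3 percentage points lower (within the scatter) from compound 3 to compound 4, 3 percentage points apart, within the scatter of two such steps. The change therefore carried from the core of compound 1 to the core of compound 3 with no difference beyond the scatter, even though the chloro does not stand at the same place in the two pairs, and in compound 4 it lies next to the ring nitrogen. Within the data shown here, this rests on only two pairs, read at one concentration, and with steps this small it does not show whether the change would carry over on a core with a stronger effect in this read-out.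

The compounds shown leave open whether a group other than chloro on the same aromatic carbon, such as an amine or a carboxylic acid, would leave the read-out as level. They also leave open what a longer chain in place of the methoxy group would do on either core.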